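The source may hold more compounds than are shown below. What is called first, only, known or untested is meant among the compounds shown, and "the series" means these compounds.

Of the compounds shown here, three that share one core have been measured in an ADME assay on BCBL1 cells (Homo sapiens) for cytotoxicity, with a stated time of 7 days; on this read-out higher numbers stand for lower toxicity in this test and lower numbers for higher toxicity in this test. Compound 1 `CC(C)CSc1nc(N)nc2c1ncn2/C=C1/CC1(CO)CO` carries an isobutylsulfanyl group on an aromatic carbon; in this assay compound 1 gives only the assay limit of > 20000 nM, not a number. Compound 2 `CCCOc1nc(N)nc2c1ncn2/C=C1/CC1(CO)CO` carries propoxy on an aromatic carbon; in this assay compound 2 likewise gives only the limit of > 20000 nM. Among the compounds with values here, compound 3 `Nc1nc(NCc2ccccc2)c2ncn(/C=C3/CC3(CO)CO)c2n1` carries benzylamino on an aromatic carbon, and in this assay compound 3 gives 19900 nM, the only actual number among the three. The steps of a number no higher from compound 1 to compound 3 (the limit leaves the size open) and a number no higher from compound 2 to compound 3 (the limit leaves the size open) are of unknown size, since two of the three results sit at the limit of > 20000 nM in this assay, at which 2 of the 3 values shown sit.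

Compound 4 `CCCCNc1nc(N)nc2c1ncn2/C=C1/CC1(CO)CO` differs from compound 3 by propyl in place of phenyl on a saturated chain carbon bound to a nitrogen on an aromatic ring. Both measured steps that end at compound 3 leave their size open, so nothing in this assay points to a step beyond the usual scatter for compound 4, and the result may again come back as a limit rather than a number. Compound 4 is therefore expected to give about 20000 nM, between 10000 nM and 40000 nM. The expected step is a 1.0-fold higher number from compound 3 to compound 4 (0.00 log units; within the scatter).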

Compound 4, half-maximal cytotoxic concentration: > 20000 nM
Compound 4: no number, only a limit (the forecaster's own chance of this, stated with the estimate: 60%); the middle value sits exactly at the limit.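

Replacing phenyl with propyl on a saturated chain carbon bound to a nitrogen on an aromatic ring gives a number no lower from compound 3 to compound 4 (the limit leaves the size open). In this assay compound 4 gives only a limit, > 20000 nM, not a number, so this result shows that a group joined through nitrogen can also reach the limit when it carries no phenyl. The steps from compound 1 and from compound 2 to compound 4 cannot be read, and nearly the whole set now rests at one limit: the limit of > 20000 nM in this assay, at which 3 of the 4 values shown sit.

From the compounds shown here alone, how far the compounds at the limit lie from one another stays open, and so does the true size of the step to compound 4. Going by these compounds, it is also open whether a longer chain, a piperidine or a carboxylic acid at this place would give a clearly lower number.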